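The compounds below may be only part of what the source reports. "The series", "measured", "known", "first", "only" and "open" are said of these compounds alone.

In an ADME assay (Homo sapiens) for pharmacokinetics (a lower number here means slower removal, a higher number faster removal of the compound), compound 3 `Cc1c(CF)nnc2sc(C(=O)NC3CN(c4ncc(C(F)(F)F)cn4)C3)c(N)c12` gives 10.8 mL/min/kg. Compound 1 `Cc1c(C(F)F)nnc2sc(C(=O)NC3CN(c4ncc(C(F)(F)F)cn4)C3)c(N)c12` gives 10.1 mL/min/kg and compound 2 `Cc1c(Cl)nnc2sc(C(=O)NC3CN(c4cc(C(F)(F)F)ncc4Cl)C3)c(N)c12` gives 14.7 mL/min/kg. Compound 3 stands within the scatter of both, so these numbers do not separate it from either compound. The next structure, compound 4 `COc1nnc2sc(C(=O)NC3CN(c4ncc(C(F)(F)F)cn4)C3)c(N)c2c1C`, carries methoxy in place of fluoromethyl on an aromatic carbon. For the measured compounds named here, the one measured step that bears on this place is a 1.1-fold higher number from compound 1 to compound 3 (0.03 log units; within the scatter), with hydrogen in place of fluoro on a saturated chain carbon, and it stays within the scatter. Going by the values given here, compound 2 differs from compound 3 in more than one place, so it offers no single step. Among the compounds with values here, no measured compound carries methoxy, so the data do not test this exchange directly. No step beyond the scatter is therefore expected in this assay, though confidence is limited and the range is kept wide. The expected size is a 1.1-fold higher number from compound 3 to compound 4 (0.05 log units; within the scatter). For compound 4 the estimate is 12 mL/min/kg, with an expected range of 6 mL/min/kg to 22 mL/min/kg.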

Compound 4, clearance: 2.52 mL/min/kg
For compound 4 the middle estimate is 4.8-fold (0.68 log units) above the measured one, outside the stated range (below it).
By their numbers in this assay, from the lowest: compound 4; then compounds 1, 3 and 2 (each within the scatter of the next).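

On the aromatic carbon next to the ring nitrogen, this position does affect this assay: methoxy in place of fluoromethyl gives (a 4.3-fold lower number from compound 3 to compound 4 (0.63 log units; beyond the scatter)), and methoxy in place of difluoromethyl gives (a 4.0-fold lower number from compound 1 to compound 4 (0.60 log units; beyond the scatter)). The only earlier step at this place, between the two fluorinated groups (a 1.1-fold higher number from compound 1 to compound 3 (0.03 log units; within the scatter)), had shown no such movement, so among the compounds shown, methoxy stands apart from both fluorinated chains. Nothing available explains the shift.

On these data alone, it remains open whether an ethoxy chain or an amine at this position would give a number close to that of compound 4. As far as these compounds go, it is also open whether methoxy would give a step of similar size with the other groups carried by compound 2.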